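The source may report more compounds than this note shows. Statements on the series, on what has been measured and on what is new or still open speak of the compounds shown alone.

Two compounds of the series carry numbers in a functional assay on HeLa cells (Homo sapiens) for antiproliferative activity, with a stated time of 24 h; on this read-out higher numbers stand for weaker inhibition and lower numbers for stronger inhibition. Compound 1 `NC(=O)c1c(NC(=O)c2ccccc2Cl)sc2c1CCN(Cc1ccc(Cl)cc1)C2` reaches only a limit of the assay, > 50000 nM, which is the point at the limit of > 50000 nM in this assay, at which 1 of the 2 values shown sits. Among the compounds with values here, compound 2 `NC(=O)c1c(NC(=O)c2ccccc2Cl)sc2c1CCN(C(=S)Nc1ccccc1C(F)(F)F)C2` gives 26700 nM, the only real number so far. Compound 3 `Cc1ccccc1NC(=S)N1CCc2c(sc(NC(=O)c3ccccc3Cl)c2C(N)=O)C1` is not yet measured; it differs from compound 2 by methyl in place of trifluoromethyl on an aromatic carbon. Within the data shown here, with no measured step between compounds to lean on, the expected step in this assay is a 1.1-fold higher number from compound 2 to compound 3 (0.05 log units; within the scatter), not beyond the scatter and with no preferred direction. Compound 3 is therefore estimated at 30000 nM, within 10000 nM to 80000 nM.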

Compound 3, half-maximal inhibitory concentration: > 50000 nM
Compound 3 was reported as a limit; the forecaster's own chance of this, stated with the estimate: 30%; middle value at least 1.6-fold (0.22 log units) from the limit.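

Within the data shown here, on the aromatic carbon of the 2-(trifluoromethyl)phenyl group, methyl in place of trifluoromethyl gives the first readable step in this assay, an at least 1.8-fold higher number from compound 2 to compound 3 (0.27 log units; that floor lies within the scatter), and with that floor a real loss is not established. Compound 3 is reported only as a limit of the assay, as compound 1 is: the limit of > 50000 nM in this assay, at which 2 of the 3 values shown sit. The step from compound 1 to compound 3 cannot be read.

Going by these compounds, whether trifluoromethyl matters at this carbon therefore stays open. Also open, on these data alone, is how an amine or a carboxylic acid would read in its place.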